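Two Limits and a Methyl Ester Question

This account rests on a few compounds, and the source may have more. Where it says the series, first, only, none or still open, it means among the compounds named here.

In an ADME assay on cells (Fibroblast, Homo sapiens) for antiproliferative activity, with a stated time of 48 h (a lower number here means a stronger inhibitor, a higher number a weaker inhibitor), compound 1 (`CCN(CC)c1ccc(-c2ccc(C#N)cc2)nn1`) gives > 25000 nM, which is a limit and not a number. Compound 2 (`CCN(CC)c1ccc(-c2ccc(C(C)=O)cc2)nn1`) gives > 25000 nM, also a limit. Both compounds therefore sit at one ceiling: the limit of > 25000 nM in this assay, at which 2 of the 2 values shown sit. Compound 3 (`CCN(CC)c1ccc(-c2ccc(C(=O)OC)cc2)nn1`) carries methoxy in place of methyl on a carbonyl carbon. Within the data shown here, the only measured step, a step that the two limits leave unreadable from compound 1 to compound 2, offers no readable size to build on. No change beyond the scatter is therefore expected in this assay, and the estimated step is a step that the limit leaves unreadable from compound 2 to compound 3. For compound 3 the expected value is 30000 nM, with an estimated range of 15000 nM to 60000 nM.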

Compound 3, half-maximal inhibitory concentration: 100 nM
Beside the measured number, compound 3's estimate is 300-fold (2.48 log units) above it; the whole stated range lies above it.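

In this assay, methoxy in place of methyl on a carbonyl carbon gives an at least 250-fold lower number from compound 2 to compound 3 (2.39 log units; beyond the scatter), and replacing the nitrile with methoxycarbonyl gives an at least 250-fold lower number from compound 1 to compound 3 (2.39 log units; beyond the scatter). A carbonyl alone does not separate these compounds: compound 2 carries one too, and its value is only a limit. Compound 3 alone now stands off the ceiling: the limit of > 25000 nM in this assay, at which 2 of the 3 values shown sit.

The compounds shown leave open whether methoxy itself is needed, or whether a carboxylic acid, an amide or a longer ester chain on the same carbonyl carbon would serve as well.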